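The source may report more compounds than this note shows. Statements on the series, on what has been measured and on what is new or still open speak of the compounds shown alone.

Compound 1 `OC[C@H]1O[C@@H](n2cnc3c(NCc4ccccc4Cl)ncnc32)[C@H](O)[C@@H]1O` anchors this small set. Among the compounds with values here, in a functional assay on K562 cells (Homo sapiens) for antiproliferative activity, with a stated time of 72 h (a higher number here means a weaker inhibitor, a lower number a stronger inhibitor), compound 1 gives 64000 nM, and this is the only proper number among the three values shown. Compound 2 `Cc1cccc(CNc2ncnc3c2ncn3[C@@H]2O[C@H](CO)[C@@H](O)[C@H]2O)c1` reaches only a limit of the assay in this assay, > 166000 nM. Compound 3 `COc1cccc(CNc2ncnc3c2ncn3[C@@H]2O[C@H](CO)[C@@H](O)[C@H]2O)c1` likewise reaches only a limit, > 166000 nM. The two measured steps away from compound 1 are thus an at least 2.5-fold higher number from compound 1 to compound 2 (0.41 log units; beyond the scatter) and an at least 2.5-fold higher number from compound 1 to compound 3 (0.41 log units; beyond the scatter), each an at least modest weakening and each ending at the limit of > 166000 nM in this assay, at which 2 of the 3 values shown sit. Between compound 2 and compound 3 the step that the two limits leave unreadable from compound 2 to compound 3 cannot be read from two limits.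

Compound 4 `OC[C@H]1O[C@@H](n2cnc3c(NCc4ccc(Cl)cc4Cl)ncnc32)[C@H](O)[C@@H]1O` differs from compound 1 by chloro in place of hydrogen on an aromatic carbon. Neither measured step touches the same place: each of them exchanges the 2-chlorophenyl for a differently substituted ring, whereas compound 4 keeps the 2-chlorophenyl and gains a second chloro. Those steps therefore give no direct reading for this change, and with the reference itself far from potent, compound 4 is expected to show no step beyond the scatter, a 1.2-fold lower number from compound 1 to compound 4 (0.07 log units; within the scatter). Compound 4 is estimated at 55000 nM in this assay, with a range from 20000 nM to 166000 nM.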

Compound 4, half-maximal inhibitory concentration: 106000 nM
Compound 4: middle estimate off by 1.9-fold (0.28 log units), on the low side; low and high end bracket the measured number.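

Chloro in place of hydrogen at this position, on the aromatic carbon para to a large group and meta to the chloro group, gives in this assay a 1.7-fold higher number from compound 1 to compound 4 (0.22 log units; within the scatter). Within the data shown here, the earlier steps exchanged the whole substituted ring, so this is the first reading of a single added group on the ring that compound 1 carries, and it shows that the 2,4-dichlorophenyl stays within the scatter of the 2-chlorophenyl. Against the other two rings the readings are an at least 1.5-fold lower number from compound 3 to compound 4 (0.19 log units; that floor lies within the scatter) and an at least 1.5-fold lower number from compound 2 to compound 4 (0.19 log units; that floor lies within the scatter), so neither step shows a gap beyond the scatter, and both can be given only as floors: the limit of > 166000 nM in this assay, at which 2 of the 4 values shown sit.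

Whether any group on this aromatic carbon can move the number beyond the scatter remains open, since chloro is the only one shown there, and an amine, a hydroxyl or a carboxylic acid at the same place could read differently. Also open is how the ring behaves with no chloro at all, as a plain benzyl group is not among the compounds shown here.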